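This account rests on a few compounds, and the source may have more. Where it says the series, first, only, none or still open, it means among the compounds named here.

In an in vitro ADME assay on microsomes from liver (Rattus norvegicus) for metabolic stability, read by LC-MS, using NADPH, tested at 1 uM (a lower number here means that the compound disappears faster, a higher number that the compound lasts longer), compound 3 `CC(C)CN1C(=O)CN(Cc2ccc(-c3ccc(F)c(CN4CCCCC4)n3)cc2)C1=O` gives 0.15 h, and compound 1 `O=C1CN(Cc2ccc(-c3ccc(F)c(CN4CCCCC4)n3)cc2)C(=O)N1CC1CC1` gives 0.2 h, the two lying within the scatter of each other. Compound 2 `CCN1C(=O)CN(Cc2ccc(-c3cccc(CN4CCCCC4)n3)cc2)C1=O` gives 0.95 h, a higher number than compound 3 and beyond the scatter.

Compound 4 `CCN1C(=O)CN(Cc2ccc(-c3ccc(F)c(CN4CCCCC4)n3)cc2)C1=O` comes from compound 3 by one change: methyl in place of isopropyl on a saturated chain carbon bound to an amide-type nitrogen in a ring. Cut one bond further out, this reads isobutyl to ethyl.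

Among the compounds with values here, the only measured step at this place, a 1.3-fold lower number from compound 1 to compound 3 (0.12 log units; within the scatter), is small and does not cover a shorter chain. More guidance comes from the ethyl that compound 4 shares with compound 2, which has no fluorine and stands at 0.95 h. With the fluorine kept, only part of that gap is expected to open. The expected move is to a higher number, a 2.7-fold higher number from compound 3 to compound 4 (0.43 log units; beyond the scatter), estimated as a modest step. For compound 4 the estimated half-life is 0.4 h, with an expected range from 0.2 h to 0.8 h.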

Compound 4, half-life: 0.517 h
Estimate against measurement, compound 4: 1.3-fold (0.11 log units) below; the measured number falls inside the stated range.
By their numbers in this assay, from the lowest: compounds 3 and 1 (each within the scatter of the next); then compounds 4 and 2 (each within the scatter of the next).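

In this assay, within the data shown here, shortening the chain on the amide-type nitrogen in the ring is the first change at this place to move the half-life beyond the scatter: methyl in place of isopropyl gives (a 3.4-fold higher number from compound 3 to compound 4 (0.54 log units; beyond the scatter)), and methyl in place of cyclopropyl gives (a 2.6-fold higher number from compound 1 to compound 4 (0.41 log units; beyond the scatter)), both with the fluorine kept. Fluoro in place of hydrogen on an aromatic carbon, read with the ethyl kept (a 1.8-fold lower number from compound 2 to compound 4 (0.26 log units; within the scatter)), stays within the scatter, so this pair gives no reading of a fluorine effect. Nothing measured here explains these steps.

On these data alone, whether the half-life keeps following chain length at this place, for instance with the amide hydrogen or a longer chain such as n-pentyl, stays open. Also open, as far as these compounds go, is whether the fluorine counts for more with the isobutyl chain than with ethyl.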